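This account rests on a few compounds, and the source may have more. Where it says the series, first, only, none or still open, it means among the compounds named here.

Measured so far:
- compound 1 `COc1ccc(CN(C(=O)C2CC2)c2cc(OC)c(OC)c(OC)c2)cc1O`: 59 nM
- compound 2 `COc1ccc(CNc2cc(OC)c(OC)c(OC)c2)cc1`: 11400 nM
- compound 3 `C/C=C/C(=O)N(Cc1ccc(OC)c(N)c1)c1cc(OC)c(OC)c(OC)c1`: 150 nM

In a functional assay on MGC-803 cells (Homo sapiens) for inhibition, read by MTT assay, with a stated time of 48 h (a lower number here means a stronger inhibitor, a higher number a weaker inhibitor), compound 1 holds the lowest of the three numbers. Compound 3 lies higher by a margin beyond the scatter, and compound 2 lies far higher still; compound 1 is thus the strongest inhibitor of the three measured.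

Compound 4 `COCC(=O)N(Cc1ccc(OC)c(O)c1)c1cc(OC)c(OC)c(OC)c1` keeps the shared core of compound 1 and differs in one place: methoxymethyl in place of cyclopropyl on a carbonyl carbon. Among the measured compounds shown here, no measured pair shows this change, so its size cannot be read from the data. The expectation is a small step toward a higher number, near the edge of the scatter, with the acyl group on the amide-type nitrogen as the only point of difference. Compound 4 is expected to give about 120 nM, in a range from 40 nM to 400 nM. The expected step is a 2.0-fold higher number from compound 1 to compound 4 (0.31 log units; beyond the scatter).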

Compound 4, half-maximal inhibitory concentration: 79 nM
The estimate for compound 4 lay 1.5-fold (0.18 log units) above the measured number, within the range that was stated.
By their numbers in this assay, from the lowest: compounds 1, 4 and 3 (each within the scatter of the next, the first and the last beyond it); then compound 2.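

In this assay the carbonyl carbon on the amide-type nitrogen accepts methoxymethyl in place of cyclopropyl, with a step of (a 1.3-fold higher number from compound 1 to compound 4 (0.13 log units; within the scatter)). The three-membered carbon ring is therefore not needed at this place to keep a number matching compound 1, and the hydrogen-bond acceptor that enters leaves the two compounds within the scatter. Nothing available accounts for this result. Open, as far as these compounds go, is whether an amine, a carboxylic acid or a longer chain at this carbonyl carbon would keep the number.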